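Swapping a Boron Group on a Quinazoline-Type Core

The source may report more compounds than this note shows. Statements on the series, on what has been measured and on what is new or still open speak of the compounds shown alone.

Measured so far:
Compound 1, `OB(O)c1ccc2ncnc(Nc3ccc(F)c(Cl)c3)c2c1`: "not active" (no number reported)
Compound 2, `COc1cc2ncnc(Nc3ccc(F)c(Cl)c3)c2cc1B(O)O`: "not active" (no number reported)
Compound 3, `OB(O)c1ccc2ncnc(Nc3cccc(Cl)c3)c2c1`: 7%

In an assay on isolated protein for inhibition of vascular endothelial growth factor receptor 1 (Homo sapiens), read by ELISA, with a stated time of 20 min, tested at 1 uM (on this read-out higher numbers stand for more inhibition at the one concentration tested (going by the name of the read-out) and lower numbers for less inhibition), compound 1 is reported as "not active" (no number reported), without a number. Compound 2 is likewise reported as "not active" (no number reported) in this assay. Compound 3 gives 7% in this assay, a small number close to no inhibition. So compound 1 has only a reported verdict in this assay and no measured number that could be set against the number for compound 3.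

Compound 4, `CC1(C)OB(c2ccc3ncnc(Nc4ccc(F)c(Cl)c4)c3c2)OC1(C)C`, differs from compound 1 in one place: a group of 9 heavy atoms (6 carbon, 1 boron, 2 oxygen; one five-membered non-aromatic ring with 3 hetero atoms) in place of a group of 3 heavy atoms (1 boron, 2 oxygen; no ring), on an aromatic carbon. The change keeps the rest of the structure and the position on the aromatic ring untouched.

Going by the values given here, no measured step covers this change. Given that compound 1 is "not active" (no number reported) in this assay and the nearest measured neighbour, compound 3, shows 7%, no movement beyond the scatter of this assay is expected in either direction.

For compound 4 the expected inhibition in this assay is 5%, with a range from 0% to 25%, and a fair chance that only "not active" is reported.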

Compound 4, a percentage reported as inhibition, at one concentration (the size of the read-out at that concentration, not a potency): 8%
Compound 4: middle estimate off by 3 percentage points, on the low side; measured number inside the range.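

In this assay, going by these compounds alone, compound 4 gives 8% while compound 1 has only the verdict "not active" (no number reported) so no step between these two compounds can be read. As far as these compounds go, whether the larger ring-bearing boron group changes inhibition stays open. No evidence here bears on this result.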